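Replacing Benzyloxy with Phenyl: Expected Potency of Compound 4

The source may report more compounds than this note shows. Statements on the series, on what has been measured and on what is new or still open speak of the compounds shown alone.

Compound 1 `Cc1cnn(-c2ccc(C)nc2C(=O)N2CC3(CC3)C[C@H]2CNc2ccc(C(F)(F)F)cn2)c1`: 8.3 in a functional assay on HEK293 cells for antagonist activity at Orexin receptor type 2 (Homo sapiens), read by FLIPR and calcium flux; on this read-out higher numbers stand for higher potency (the scale is a negative logarithm) and lower numbers for lower potency
Compound 2 `Cc1ccc(-c2ncccn2)c(C(=O)N2CC3(CC3)C[C@H]2CNc2ccc(C(F)(F)F)cn2)n1`: 7.5
Compound 3 `Cc1ccc(OCc2ccccc2)c(C(=O)N2CC3(CC3)C[C@H]2CNc2ccc(C(F)(F)F)cn2)n1`: 8.6

Compound 3 gives the highest of the three numbers in this assay. Its nearest neighbour is compound 1, and the step of a number 0.30 log units higher from compound 1 to compound 3 (within the scatter) stays within the scatter, so the two cannot be ranked. The step of a number 1.10 log units higher from compound 2 to compound 3 (beyond the scatter) is large and beyond the scatter, and the step of a number 0.80 log units lower from compound 1 to compound 2 (beyond the scatter) is modest.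

Compound 4 `Cc1ccc(-c2ccccc2)c(C(=O)N2CC3(CC3)C[C@H]2CNc2ccc(C(F)(F)F)cn2)n1` is the next compound, and it differs from compound 3 by phenyl in place of benzyloxy on an aromatic carbon. For the measured compounds named here, no measured step exchanges benzyloxy for phenyl at this position, so the expectation rests on the other groups seen there: a directly attached aromatic ring, pyrimidin-2-yl, gave the lowest number of the three in compound 2, while the directly attached 4-methyl-1H-pyrazol-1-yl in compound 1 sat within the scatter of compound 3. Phenyl is again a directly attached ring, so a drop of modest size is expected, though it may not pass the scatter. Compound 4 is therefore estimated at 8, with a range from 7.3 to 8.7, which means an expected step of a number 0.60 log units lower from compound 3 to compound 4 (beyond the scatter).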

Compound 4, negative logarithm of the antagonist equilibrium constant: 8
The estimate for compound 4 equals the measured number at the digits printed, and the stated range covers the measured number.
By their numbers in this assay, from the lowest: compound 2; then compounds 4, 1 and 3 (each within the scatter of the next, the first and the last beyond it).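

With both groups carrying one six-membered aromatic ring of carbon only, the step of a number 0.60 log units lower from compound 3 to compound 4 (beyond the scatter) shows in this assay that the way this ring is attached at this position can move the number beyond the scatter. Among the directly attached rings, the step of a number 0.50 log units higher from compound 2 to compound 4 (beyond the scatter) shows that such rings do not all give the same number here, while the step of a number 0.30 log units lower from compound 1 to compound 4 (within the scatter) leaves phenyl and 4-methyl-1H-pyrazol-1-yl unranked. Nothing available explains why these groups give the numbers they do.

The compounds shown leave open how a ring joined through a single oxygen, as in phenoxy, or through a longer chain, as in 2-phenylethoxy, would compare with benzyloxy at this position. They also leave open whether a group without an aromatic ring, such as the amine morpholine or a carboxylic acid, would be tolerated at this position in the same way as the aromatic groups seen so far.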